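Removing the bromo group from compound 2

A few compounds are considered here, and "the series" means these few. Any claim that something is new, unique, unknown or untested is made for them only; others in the source may bear on it.

Of the compounds shown here, two on the shared core have been read in a functional assay on HeLa cells (Homo sapiens) for antiproliferative activity, read by MTT assay, with a stated time of 24 h; a lower number here means a stronger inhibitor, a higher number a weaker inhibitor. Compound 1 `COC(=O)c1scc(-c2ccc(NC(=O)c3ccccn3)cc2)c1OC` gives > 50000 nM, and this value is a limit of the assay. Going by the values given here, compound 2 `COC(=O)c1scc(-c2ccc(NC(=O)c3ccc(C(F)(F)F)cc3Br)cc2)c1OC` gives 16200 nM, the only actual number so far. Compound 3 `COC(=O)c1scc(-c2ccc(NC(=O)c3ccc(C(F)(F)F)cc3)cc2)c1OC` differs from compound 2 in one place, hydrogen in place of bromo on an aromatic carbon, ortho to a large group and meta to a trifluoromethyl group. Among the compounds with values here, no measured single-place step is available to size this change, so the expectation rests on compound 2 at 16200 nM alone. The expected step of a 1.5-fold higher number from compound 2 to compound 3 (0.19 log units; within the scatter) is modest, towards weaker inhibition in this assay, and may not clear the scatter. For compound 3 the estimated value is 25000 nM, with an expected range of 11000 nM to 55000 nM.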

Compound 3, half-maximal inhibitory concentration: 14400 nM
Compound 3: the middle estimate sits 1.7-fold (0.24 log units) above what was measured; the measured number falls inside the stated range.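

Hydrogen in place of bromo on this aromatic carbon, ortho to a large group and meta to a trifluoromethyl group, gives a 1.1-fold lower number from compound 2 to compound 3 (0.05 log units; within the scatter) in this assay, so activity at this level does not depend on the bromo group. Going by these compounds alone, this is the first sized step at this position, and it shows no readable change. The other step, 4-(trifluoromethyl)phenyl in place of pyridin-2-yl on a carbonyl carbon, is an at least 3.4-fold lower number from compound 1 to compound 3 (0.54 log units; beyond the scatter) and lies beyond the scatter, but its full size cannot be read because its weaker end is a limit of the assay: the limit of > 50000 nM in this assay, at which 1 of the 3 values shown sits.

From the compounds shown here alone, it remains open whether another group on this aromatic carbon, such as an amine or a nitrile, would move the number beyond the scatter. Going by these compounds, it also remains open how much of the step on the carbonyl carbon depends on the trifluoromethyl group, which a plain phenyl there would address.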